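Pyrimidinyl thiourea and fused analogues against barnyard grass

A few compounds are considered here, and "the series" means these few. Any claim that something is new, unique, unknown or untested is made for them only; others in the source may bear on it.

Measured so far:
compound 1 `COc1cc(SC)nc(NC(=S)NC(=O)c2c(-c3ccc(Cl)cc3Cl)noc2C)n1` gives 40.9%
compound 2 `Cc1onc(-c2ccc(Cl)cc2Cl)c1C(=O)/N=c1/nc2nc(Cl)cc(C)n2s1` gives 55.6%
compound 3 `COc1cc(OC)n2s/c(=N\C(=O)c3c(-c4ccc(Cl)cc4Cl)noc3C)nc2n1` gives 85.6%

All three share the same core and were tested in a functional assay on the whole organism (strain L.) for inhibition, with Echinochloa crus-galli as the target, with a stated time of 72 h, tested at 100 mg/L; a higher number here means more inhibition of growth at the concentration tested, a lower number less inhibition of growth. Compound 1 stands lowest of the three numbers. Its nearest neighbour is compound 2, whose value lies higher by an amount beyond the scatter; compound 3 lies furthest away, higher again by an amount well beyond the scatter. Among the compounds with values here, no pair of these measured compounds differs in a single place, so no measured step is available to guide a change at the pyrimidinyl group.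

Compound 4 `Cc1cc(Cl)nc(NC(=S)NC(=O)c2c(-c3ccc(Cl)cc3Cl)noc2C)n1` has not yet been measured. It differs from compound 1 in one place: 4-chloro-6-methylpyrimidin-2-yl in place of 4-methoxy-6-(methylsulfanyl)pyrimidin-2-yl on an amide-type nitrogen. Nothing measured here shows how this exchange acts; compounds 2 and 3 carry their pyrimidine within a fused system and are not directly comparable.

Expectation: the step of a number 1.1 percentage points higher from compound 1 to compound 4 (within the scatter) is estimated to be small, with no clear direction beyond the scatter. For compound 4 in this assay the estimate is 42%, within a range of 20% to 65%, reflecting the absence of any measured step at this position.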

Compound 4, percent growth inhibition at one concentration: 48.7%
Beside the measured number, compound 4's estimate is 6.7 percentage points below it, and the stated range covers the measured number.
By their numbers in this assay, from the lowest: compounds 1, 4 and 2 (each within the scatter of the next, the first and the last beyond it); then compound 3.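

In this assay the pyrimidinyl group on the amide-type nitrogen now has its first measured step, a number 7.8 percentage points higher from compound 1 to compound 4 (within the scatter) with 4-chloro-6-methylpyrimidin-2-yl in place of 4-methoxy-6-(methylsulfanyl)pyrimidin-2-yl. This exchange replaces two groups of the pyrimidine at once and drops the count of hydrogen-bond acceptors in the substituent from 4 to 2, yet the two thioureas cannot be told apart in this read-out at the single concentration tested, so this position accepts this particular change without a step beyond the scatter. Nothing available bears on why the two compounds read alike.

Because both groups change together in this one step, the compounds shown do not separate the part played by the chloro group from that of the methyl group, and a partner that would change only one of them is still needed. Also open, going by these compounds, is whether a different kind of group on the pyrimidine, such as a dimethylamino group or a longer chain like n-butoxy in place of the methylsulfanyl group, would give a step beyond the scatter in this assay at this position.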